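Moving a Methoxy Group Around a Benzyl Ether

A few compounds are considered here, and "the series" means these few. Any claim that something is new, unique, unknown or untested is made for them only; others in the source may bear on it.

Compound 1 `COc1cccc(OC)c1OCCNCCOc1ccccc1OCc1ccc(C)cc1` and compound 2 `COc1ccccc1COc1ccccc1OCCNCCOc1c(OC)cccc1OC` differ in only one place, the group carried on a saturated chain carbon bound to an oxygen on an aromatic ring. In a functional assay on spleen for antagonist activity at Alpha-1B adrenergic receptor (Rattus norvegicus) (a higher number here means a more potent compound, by a factor of ten per unit of this negative logarithm, a lower number a less potent compound), compound 1 gives 8.43, and compound 2 gives 8.13. Among the compounds with values here, the single measured step, a number 0.30 log units lower from compound 1 to compound 2 (within the scatter), shows that exchanging 4-methylphenyl for 2-methoxyphenyl at this place left potency essentially unchanged. Within the data shown here, on the numbers so far compound 2 sits at the bottom of the pair, yet its nearest neighbour, compound 1, lies inside the usual scatter of it, so the two cannot really be told apart.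

Compound 3 `COc1ccc(COc2ccccc2OCCNCCOc2c(OC)cccc2OC)cc1` is the next compound to be measured. It differs from compound 2 in one place: 4-methoxyphenyl in place of 2-methoxyphenyl on a saturated chain carbon bound to an oxygen on an aromatic ring. Among the measured compounds shown here, the only measured step that bears on this change is the one between compound 1 and compound 2, which stayed within the scatter when a substituted phenyl on this carbon was swapped for another. For compound 3 a step of about a number 0.17 log units higher from compound 2 to compound 3 (within the scatter) is expected, a small upward drift that stays within the scatter. The estimate for compound 3 in this assay is therefore 8.3, with a range from 7.8 to 8.8.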

Compound 3, negative logarithm of the antagonist equilibrium constant: 9.51
For compound 3 the middle estimate is 1.21 log units below the measured one, and the stated range ends below it.
By their numbers in this assay, from the lowest: compounds 2 and 1 (each within the scatter of the next); then compound 3.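

This place, on a saturated chain carbon bound to an oxygen on an aromatic ring, turns out to be far less forgiving than the first pair suggested: in this assay, moving the methoxy from 2-methoxyphenyl to 4-methoxyphenyl, with the same atoms joined differently, gives a number 1.38 log units higher from compound 2 to compound 3 (beyond the scatter). The identity of the group matters as well, since methoxy in place of methyl on an aromatic carbon, which turns 4-methylphenyl into 4-methoxyphenyl, gives a number 1.08 log units higher from compound 1 to compound 3 (beyond the scatter). Compound 3 is therefore the most potent of the three, and the close values of compounds 1 and 2 cannot be read as a sign that any substituted phenyl works equally well here.

No measurement at hand explains why 4-methoxyphenyl stands apart from the other two groups. As far as these compounds go, it also remains open whether this rise is special to methoxy or would also appear with 4-hydroxyphenyl or 4-chlorophenyl at this place, and whether 2-methylphenyl would show the same dependence on where the group sits.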